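Replacing an aminophenyl by a difluorophenyl on the shared core

The source may hold more compounds than are shown below. What is called first, only, known or untested is meant among the compounds shown, and "the series" means these compounds.

Compound 1, `COc1cc(-c2cc(/C=C/C(=O)c3ccc(N)cc3)[nH]n2)cc(OC)c1OC`, carries a 4-aminophenyl on the carbonyl carbon of its unsaturated chain. In a functional assay on SR cells (Homo sapiens) for inhibition, read by sulforhodamine B assay, with a stated time of 48 h (on this read-out higher numbers stand for lower toxicity in this test and lower numbers for higher toxicity in this test), compound 1 gives only a limit, > 100000 nM, and not a number. Compound 2, `COc1ccc(-c2cc(/C=C/C(=O)c3ccc(N)cc3)[nH]n2)cc1OC`, differs from it by a hydrogen in place of a methoxy on an aromatic carbon; in this assay compound 2 also gives only a limit, > 100000 nM. The step from compound 1 to compound 2 is therefore a step that the two limits leave unreadable from compound 1 to compound 2. Compound 3, `COc1cc(C(=O)/C=C/c2cc(-c3cc(OC)c(OC)c(OC)c3)n[nH]2)cc(OC)c1OC`, with the same trimethoxyphenyl on both ends of the core, likewise gives only a limit in this assay, > 100000 nM. Taken together, (the limit of > 100000 nM in this assay, at which 3 of the 3 values shown sit), so nothing in the measured set reads as a step of known size.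

Compound 4, `COc1cc(-c2cc(/C=C/C(=O)c3ccc(F)c(F)c3)[nH]n2)cc(OC)c1OC`, has not yet been measured in this assay. It differs from compound 1 by 3,4-difluorophenyl in place of 4-aminophenyl on a carbonyl carbon. Among the measured compounds shown here, no measured step bears on this exchange, since the only measured step, from compound 1 to compound 2, is unreadable. The expectation for compound 4 in this assay is thus a value that again sits near the limit, with the step from compound 1 to compound 4 estimated as a number no higher from compound 1 to compound 4 (the limit leaves the size open). Compound 4 is estimated at 100000 nM, with a range from 20000 nM to 300000 nM.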

Compound 4, concentration lethal to 50% of the cells: > 100000 nM
Compound 4 was reported as a limit (the forecaster's own chance of this, stated with the estimate: 65%); the middle value sits exactly at the limit.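

Compound 4, like compound 1, gives only a limit and not a number in this assay, so no size can be read for the step from 4-aminophenyl to 3,4-difluorophenyl. Whether any exchange among the compounds shown changes the toxicity in this test, and by how much, stays open, as every value rests at one limit: the limit of > 100000 nM in this assay, at which 4 of the 4 values shown sit.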